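Removing a Nitro Group from an Aryl Triazene

The compounds below may be only part of what the source reports. "The series", "measured", "known", "first", "only" and "open" are said of these compounds alone.

Compound 2, `CN(C)/N=N/c1ccc([N+](=O)[O-])cc1C(N)=O`, and compound 1, `CN(CCO)/N=N/c1ccccc1C(N)=O`, are the two measured compounds. In a functional assay on L1210 cells (Mus musculus) for antiproliferative activity (on this read-out lower numbers stand for lower potency and higher numbers for higher potency (the scale is a negative logarithm)), compound 2 gives 3.26, and compound 1 gives 3.07; these two numbers lie within the usual scatter of each other, so neither stands apart. Compound 3, `CN(C)/N=N/c1ccccc1C(N)=O`, has not yet been measured. It differs from compound 2 by hydrogen in place of nitro on an aromatic carbon. For the measured compounds named here, no measured pair shows this change, so nothing here points to a step beyond the scatter in either direction. Compound 3 is therefore expected to give about 3.1, with a likely range from 2.6 to 3.6. This estimate means a step of a number 0.16 log units lower from compound 2 to compound 3 (within the scatter), which is expected to stay within the scatter.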

Compound 3, logarithm of the reciprocal of the active concentration, log(1/C): 3.31
Beside the measured number, compound 3's estimate is 0.21 log units below it, within the range that was stated.
By their numbers in this assay, from the lowest: compounds 1, 2 and 3 (each within the scatter of the next).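

In this assay hydrogen in place of nitro on the aromatic carbon gives a number 0.05 log units higher from compound 2 to compound 3 (within the scatter) and so shows that the read-out holds without the nitro group at this position. Hydrogen in place of hydroxymethyl on the chain carbon bound to the amine nitrogen gives a number 0.24 log units higher from compound 1 to compound 3 (within the scatter) as well. Nothing available explains why either change leaves the number within the scatter.

The compounds shown leave open what an amine or a carboxylic acid on this aromatic carbon would give. They also leave open how a longer chain on the amine nitrogen would read.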